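The compounds below may be only part of what the source reports. "The series", "measured", "known", "first", "only" and "open" are said of these compounds alone.

Measured in a functional assay, read by spectrophotometry; a higher number here means that more compound is needed for the effect, a lower number that less compound is needed:

- compound 1 `COc1cc(-c2cc(=O)c3ccc(O)cc3o2)cc(OC)c1OC`: 26.4 nM
- compound 2 `COc1ccc(-c2cc(=O)c3ccc(OCCCN4CCC(CCO)CC4)cc3o2)cc1`: 22.8 nM
- compound 3 `COc1ccc(-c2cc(=O)c3ccc(OCCCCN4CCC(C)CC4)cc3o2)cc1`: 28.1 nM

Compound 2 stands level with the other two compounds, its value lying within the scatter of both. Compound 4 `COc1ccc(-c2cc(=O)c3ccc(OCCCCCCN4CCC(C)CC4)cc3o2)cc1` differs from it by one exchange (3-(4-methylpiperidin-1-yl)propyl in place of 4-(2-hydroxyethyl)piperidin-1-yl on a saturated chain carbon, three bonds along the chain from an oxygen on an aromatic ring): 3-(4-methylpiperidin-1-yl)propyl in place of 4-(2-hydroxyethyl)piperidin-1-yl. Going by the values given here, the only measured step that bears on this is a 1.2-fold higher number from compound 2 to compound 3 (0.09 log units; within the scatter), which brings in (4-methylpiperidin-1-yl)methyl at the same place. Among the compounds with values here, no measured compound carries the 3-(4-methylpiperidin-1-yl)propyl group, so this one small step is a limited guide. The expected change in this assay is a 1.4-fold higher number from compound 2 to compound 4 (0.16 log units; within the scatter), with no clear shift beyond the scatter anticipated. For compound 4 the estimated value is 33 nM, with an expected range from 12 nM to 90 nM.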

Compound 4, half-maximal effective concentration: 32.6 nM
Compound 4: middle estimate off by 1.0-fold (0.01 log units), on the high side, within the range that was stated.
By their numbers in this assay, from the lowest: compounds 2, 1, 3 and 4 (each within the scatter of the next).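

The exchange of 4-(2-hydroxyethyl)piperidin-1-yl for 3-(4-methylpiperidin-1-yl)propyl gives a 1.4-fold higher number from compound 2 to compound 4 (0.16 log units; within the scatter), so this position also accepts the longer group without a shift beyond the scatter. Lengthening the chain that carries the 4-methylpiperidin-1-yl group gives a 1.2-fold higher number from compound 3 to compound 4 (0.06 log units; within the scatter), so compounds 3 and 4 show no effect of chain length here. Nothing at hand explains this flat result. Going by these compounds, whether a still longer chain would stay level remains open, as does whether a morpholine or a carboxylic acid in place of the 4-methylpiperidin-1-yl group would move the number beyond the scatter.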